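Removing one methoxy group from compound 2

The compounds below may be only part of what the source reports. "The series", "measured", "known", "first", "only" and "open" are said of these compounds alone.

Two compounds of the series carry a reading in a functional assay on CCRF-CEM cells (Homo sapiens) for cytotoxicity, read by sulforhodamine B assay, with a stated time of 48 h, tested at 1 uM; on this read-out higher numbers stand for a weaker effect at the one concentration tested and lower numbers for a stronger effect. Compound 1 `COc1ccc(-c2cc(/C=C/C(=O)c3ccc(N)cc3)[nH]n2)cc1` gives 61% there. Compound 2 `COc1cc(-c2cc(/C=C/C(=O)c3ccc(N)cc3)[nH]n2)cc(OC)c1OC` gives 36% in this assay, the lowest of the two numbers, and its gap to compound 1 lies beyond the usual scatter, so compound 2 shows the stronger effect of the pair at the single concentration tested.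

Compound 3 `COc1ccc(-c2cc(/C=C/C(=O)c3ccc(N)cc3)[nH]n2)cc1OC` has not yet been measured in this assay. It differs from compound 2 in one place: hydrogen in place of methoxy on an aromatic carbon. Going by the values given here, no measured pair differs in exactly this way, so no step is available to set the size of the change directly. Going from one methoxy group in compound 1 to three in compound 2 lowers the reading, and compound 3 carries two. Compound 3 is therefore expected to land between the two measured values, a shift of a number 12 percentage points higher from compound 2 to compound 3 (beyond the scatter). Compound 3 is estimated at 48% in this assay, within a range of 32% to 64%.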

Compound 3, a percentage reported as activity, at one concentration (the size of the read-out at that concentration, not a potency): 68%
Compound 3: middle estimate off by 20 percentage points, on the low side; the measured number lies above the stated range.
By their numbers in this assay, from the lowest: compound 2; then compounds 1 and 3 (each within the scatter of the next).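

In this assay, going by these compounds alone, the methoxy group on this aromatic carbon, ortho to a methoxy group and meta to a large group, turns out to matter far more than the earlier compounds could show: hydrogen in its place gives a number 32 percentage points higher from compound 2 to compound 3 (beyond the scatter), which removes the stronger effect seen for compound 2 at the single concentration tested. The other single change behaves quite differently, since methoxy in place of hydrogen on an aromatic carbon gives a number 7 percentage points higher from compound 1 to compound 3 (within the scatter), so compound 1 and compound 3 cannot be told apart, and among these three compounds the reading does not follow a simple count of methoxy groups. No measurement at hand bears on why this one group weighs so heavily.

The compounds shown leave open whether methoxy is specifically required at this place, or whether a hydroxy group, an ethoxy group or a chlorine atom there would keep the reading of compound 2. They also leave open whether the large step depends on the two remaining methoxy groups, and whether it would persist with an amide in place of the amine on the other aromatic ring.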